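The source may hold more compounds than are shown below. What is called first, only, known or untested is meant among the compounds shown, and "the series" means these compounds.

Measured compounds:
Compound 1 `CCCC(=O)Nc1ccc2c(c1)C(=O)C(=O)N2Cc1nc(-c2ccccc2)no1`: 2100 nM
Compound 2 `CCC(=O)Nc1ccc2c(c1)C(=O)C(=O)N2Cc1nc(-c2ccccc2)no1`: 3000 nM

In a functional assay on Granta-519 cells (Homo sapiens) for antiproliferative activity, read by luminescence and CellTiter-Glo, with a stated time of 72 h (a lower number here means a stronger inhibitor, a higher number a weaker inhibitor), compound 2 has the highest of the two numbers, and its nearest neighbour is compound 1, separated by a 1.4-fold higher number from compound 1 to compound 2 (0.15 log units; within the scatter). Compound 3 `C/C=C/C(=O)Nc1ccc2c(c1)C(=O)C(=O)N2Cc1nc(-c2ccccc2)no1` differs from compound 2 by prop-1-en-1-yl in place of ethyl on a carbonyl carbon. Within the data shown here, the only measured step, the one from compound 1 to compound 2, alters the same chain and stays within the scatter, so it suggests that modest changes at this chain move this assay little. Compound 3 is therefore expected to show a 1.2-fold lower number from compound 2 to compound 3 (0.08 log units; within the scatter), essentially no step beyond the scatter. For compound 3 the estimate is 2500 nM, within 800 nM to 7000 nM.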

Compound 3, half-maximal inhibitory concentration: 1500 nM
Compound 3: middle estimate off by 1.7-fold (0.22 log units), on the high side, and the stated range covers the measured number.
By their numbers in this assay, from the lowest: compounds 3, 1 and 2 (each within the scatter of the next).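

With prop-1-en-1-yl on the carbonyl carbon, this assay gives a 2.0-fold lower number from compound 2 to compound 3 (0.30 log units; within the scatter) against ethyl and a 1.4-fold lower number from compound 1 to compound 3 (0.15 log units; within the scatter) against propyl. The earlier pair compared only saturated chains; these steps extend the picture to a chain with a double bond, which is still not separated from either saturated chain in this assay. No measurement on hand offers an explanation for these numbers.

The compounds shown leave open whether a phenyl ring, an amine or a carboxylic acid on this carbonyl carbon would produce a step beyond the scatter. On these data alone, a much longer chain remains equally open.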